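Replacing an Amide-Bearing Side Chain with an Aryl Imine

This account rests on a few compounds, and the source may have more. Where it says the series, first, only, none or still open, it means among the compounds named here.

Compound 1 `N#CC1=C(NCN2CCCC2)N(c2ccccc2)C(=O)N2CCCCC(N3CCCC3)C12` — in a functional assay on the whole organism (strain albino) for inhibition, with Rattus norvegicus as the target, read by paw edema, with stated times of 1 h and 3 h, at a dose of 20 mmol/kg by the intraperitoneal route (on this read-out lower numbers stand for a weaker effect and higher numbers for a stronger effect at the one dose given), compound 1 gives 35.3%.
Compound 2 `N#CC1=C(NCC(=O)N2CCCC2)N(c2ccccc2)C(=O)N2CCCCC(N3CCCC3)C12` — in this assay compound 2 gives 56%.
Compound 3 `N#Cc1c2n(c(=O)n(-c3ccccc3)c1=N)CCCCC2N1CCCC1` — in this assay compound 3 gives 93.4%.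

Compound 2 stands second highest of these three numbers. Its nearest neighbour is compound 1, which lies lower by more than the usual scatter; compound 3 lies further away and higher, again beyond the scatter.

Going by the values given here, only one measured step changes a single place: a number 20.7 percentage points higher from compound 1 to compound 2 (beyond the scatter), where (pyrrolidin-1-yl)carbonyl takes the place of pyrrolidin-1-yl on a saturated chain carbon bound to an amine nitrogen.

Compound 4 `COc1ccc(/C=N/C2=C(C#N)C3C(N4CCCC4)CCCCN3C(=O)N2c2ccccc2)cc1` differs from compound 2 in another way. a group of 10 heavy atoms (8 carbon, 1 nitrogen, 1 oxygen; one six-membered aromatic ring of carbon only) in place of a group of 9 heavy atoms (6 carbon, 2 nitrogen, 1 oxygen; one five-membered non-aromatic ring with 1 hetero atom), on a double-bonded ring carbon The (((pyrrolidin-1-yl)carbonyl)methyl)amino group leaves entirely, and a group containing one six-membered aromatic ring of carbon only enters at the double-bonded ring carbon.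

Among the compounds with values here, no measured step alters this group, so the one known step gives only weak guidance; compound 3, with no side chain at all, shows that this region can carry very different numbers. The step of a number 1 percentage points lower from compound 2 to compound 4 (within the scatter) is therefore expected to be small and of uncertain direction. For compound 4 the estimate is 55%, within a range from 30% to 80%.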

Compound 4, a percentage reported as inhibition, in the whole organism at one dose (the size of the read-out at that dose, not a potency): 75.3%
The estimate for compound 4 lay 20.3 percentage points below the measured number, within the range that was stated.
By their numbers in this assay, from the lowest: compound 1; then compound 2; then compound 4; then compound 3.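

The side chain on the double-bonded ring carbon need not end in a pyrrolidine ring to give a clear effect: in this assay, putting the group with a six-membered aromatic ring of carbon only in its place gives a number 19.3 percentage points higher from compound 2 to compound 4 (beyond the scatter), and a number 40 percentage points higher from compound 1 to compound 4 (beyond the scatter). Going by these compounds alone, until now, the only single-place step had changed the side chain while keeping its pyrrolidine ring, so these two steps widen the kinds of group that this position can carry while the read-out stays high at the one dose given. These are sizes of effect at that dose, not potencies, and no measurement here explains why the number rises.

The step to compound 4 replaces the whole group at once, so the compounds shown cannot say whether the higher number goes with the aromatic ring, its methoxy group or the double-bonded nitrogen link that joins it to the core. A version with a dimethylamino group or a carboxylic acid in place of the methoxy group on that ring would begin to separate these parts.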